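Trading a Chain-End Hydroxy for a Longer Alkyl Tail

A few compounds are considered here, and "the series" means these few. Any claim that something is new, unique, unknown or untested is made for them only; others in the source may bear on it.

Measured compounds:
compound 1 `Cc1c(N(C)C)nc(CCCCCCCCCCO)c(O)c1C` gives 20%
compound 2 `CCCCCCCCCCCCCCCCc1c(C)c(N2CCC2)nc(C)c1O` gives 76%
compound 3 `CCCCCCCCCCCCCCCCCCCc1c(C)c(N(C)C)nc(C)c1O` gives 103%

Of the compounds shown here, three sharing one core have been tested in a functional assay on cells (Lymphocyte), read by a luciferase reporter and ATP content, with a stated time of 48 h, tested at 10 uM; a lower number here means a stronger effect, a higher number a weaker effect of the compound at the concentration tested. Among them compound 1 stands lowest, at 20%, which means the strongest effect of the three. Compound 2 at 76% and compound 3 at 103% both lie well beyond the usual scatter above compound 1, so the difference is real, not noise. Both of those carry a long saturated chain on the core and no hydroxy at the chain end.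

The next compound is compound 4 `CCCCCCCCCCCCCCCCc1nc(N(C)C)c(C)c(C)c1O`. It differs from compound 1 in one place: hexyl in place of hydroxy on a saturated chain carbon, ten or more bonds along the chain from an aromatic carbon. Compound 4 thus joins the long-chain members of the set. Given that compound 2 gives 76% and compound 3 gives 103%, the step in this assay is expected to be upward, toward a weaker effect, by a number 52 percentage points higher from compound 1 to compound 4 (beyond the scatter). Compound 4 is estimated at 72%, with a likely range from 42% to 100%.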

Compound 4, a percentage reported as activity, at one concentration (the size of the read-out at that concentration, not a potency): 79%
The estimate for compound 4 lay 7 percentage points below the measured number; low and high end bracket the measured number.
By their numbers in this assay, from the lowest: compound 1; then compounds 2 and 4 (each within the scatter of the next); then compound 3.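

In this assay, putting hexyl in place of hydroxy on a saturated chain carbon, ten or more bonds along the chain from an aromatic carbon, gives a large move toward a weaker effect: a number 59 percentage points higher from compound 1 to compound 4 (beyond the scatter). Going by these compounds alone, compound 1 and compound 4 are the only pair here that differ in one place, so this is the first reading of the chain end on its own, and the effect of compound 1 does not survive this single change. Nothing measured here explains the size of this step.

The change removes the hydroxy and lengthens the chain together, so a chain of the same length as in compound 1 ending without the hydroxy would be needed to tell the two apart. From the compounds shown here alone, whether an amine or a carboxylic acid at the chain end could stand in for the hydroxy also remains open.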